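From 3,5-Dichlorophenyl to Pyridin-2-yl in Compound 3

The source may report more compounds than this note shows. Statements on the series, on what has been measured and on what is new or still open speak of the compounds shown alone.

In a functional assay on PANC-1 cells (Homo sapiens) for cytotoxicity, read by MTT assay, with a stated time of 72 h (on this read-out lower numbers stand for stronger inhibition and higher numbers for weaker inhibition), compound 1 (`CN1CCN(c2ccc(NC3=CC(=O)c4ncncc4C3=O)cc2)CC1`) gives 340 nM, while compound 2 (`O=C1C(Nc2ccc(-c3cc(Cl)cc(Cl)c3)cc2)=CC(=O)c2ncncc21`) gives 1900 nM, the higher of the two numbers. Compound 3 (`O=C1C(Nc2ccc(-c3ccccn3)cc2)=CC(=O)c2ncncc21`) has not yet been measured. It carries pyridin-2-yl in place of 3,5-dichlorophenyl on an aromatic carbon, para to a large group (pyridin-2-yl in place of 3,5-dichlorophenyl on an aromatic carbon). Among the measured compounds shown here, only one measured step bears on this change, and it is modest: a 5.6-fold higher number from compound 1 to compound 2 (0.75 log units; beyond the scatter), with 3,5-dichlorophenyl in place of 4-methylpiperazin-1-yl on an aromatic carbon. For the measured compounds named here, that single step shows that exchanging this group can shift the number beyond the scatter, but no measured compound carries pyridin-2-yl. A modest move towards a lower number is therefore expected, and the estimate is a 2.1-fold lower number from compound 2 to compound 3 (0.32 log units; beyond the scatter). For compound 3 the estimated value is 900 nM, with an expected range from 300 nM to 2700 nM.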

Compound 3, half-maximal inhibitory concentration: 800 nM
Estimate against measurement, compound 3: 1.1-fold (0.05 log units) above, within the range that was stated.
By their numbers in this assay, from the lowest: compound 1; then compound 3; then compound 2.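

In this assay, replacing 3,5-dichlorophenyl with pyridin-2-yl gives a 2.4-fold lower number from compound 2 to compound 3 (0.38 log units; beyond the scatter), which shows that the number at this position differs beyond the scatter between two groups that each place a six-membered aromatic ring on this carbon. The 4-methylpiperazin-1-yl group still gives the lowest number of the three, since its replacement by pyridin-2-yl gives a 2.4-fold higher number from compound 1 to compound 3 (0.37 log units; beyond the scatter), so pyridin-2-yl recovers only part of the gap between compound 1 and compound 2. Nothing available explains either step.

The three compounds leave open whether the ring nitrogen of pyridin-2-yl or the loss of the two chlorine atoms accounts for the step to compound 3. They also leave open how a morpholin-4-yl ring or an open-chain amine would behave at this position.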